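A few compounds are considered here, and "the series" means these few. Any claim that something is new, unique, unknown or untested is made for them only; others in the source may bear on it.

Measured compounds:
compound 1 `COc1ccc2c(c1)c(S(=O)(=O)c1cccc(F)c1)cn2C1CCCNC1` — 73 nM in a functional assay on HeLa cells for agonist activity at 5-hydroxytryptamine receptor 6 (Homo sapiens), read by cAMP accumulation and immunoassay, with a stated time of 10 min; a lower number here means that less compound is needed, a higher number that more compound is needed for the effect
compound 2 `COc1ccc2c(c1)c(S(=O)(=O)c1cccc(F)c1)cn2C1CCCN(C)C1` — "not determined" (no result reported) in this assay

Compound 1 and compound 2 share the same core and the same aryl sulfone; they differ only at the ring amine, which carries hydrogen in compound 1 and methyl in compound 2. Compound 2 stands nowhere on the numbers: no value was returned for it in this assay, so the only anchor in this series is compound 1 at 73 nM.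

Compound 3 `CCN1CCCC(n2cc(S(=O)(=O)c3cccc(F)c3)c3cc(OC)ccc32)C1` is the next member. Relative to compound 2 the change is methyl in place of hydrogen on a saturated chain carbon bound to an amine nitrogen in a ring. For the measured compounds named here, no step between measured compounds exists to calibrate this kind of change, and the effect of adding the first methyl (compound 1 to compound 2) is itself unknown. Against that background, the step from compound 2 to compound 3 in this assay is expected to be small, most likely within the scatter, with a slight lean toward more compound being needed rather than less.

Compound 3 is estimated at 150 nM, with a range from 30 nM to 800 nM, set wide to reflect the absence of a value for compound 2.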

Compound 3, half-maximal effective concentration: 203 nM
Estimate against measurement, compound 3: 1.4-fold (0.13 log units) below; measured number inside the range.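

For the compounds shown here, until now the amine nitrogen in the ring had only one number behind it, that of compound 1 with hydrogen, and nothing showed how this assay responds to a substituent there. Ethyl in place of hydrogen on that nitrogen now gives the first readable step at this position, a 2.8-fold higher number from compound 1 to compound 3 (0.44 log units; beyond the scatter) and this modest step means that more compound is needed, while the effect is still reached with ethyl in place. Compound 2 has no result, so the steps that run through it cannot be read, and the ethyl step stands as one whole change rather than as two additions of a single carbon. No measurement at hand speaks to the reason for this step.

As far as these compounds go, whether methyl on the same nitrogen sits nearer to hydrogen or to ethyl remains open, and two numbers define no trend with chain length. Also open, from the compounds shown here alone, is whether a longer chain such as propyl, or a benzyl group on that nitrogen, would continue the same direction, and whether the ethyl step holds with another aryl group on the sulfone.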